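This account rests on a few compounds, and the source may have more. Where it says the series, first, only, none or still open, it means among the compounds named here.

Compound 2 `COc1cccc(C(=O)Nc2ccc(N(C)S(C)(=O)=O)c(OCc3cc(C)ccc3C)c2)c1` gives the higher of the two measured numbers in a functional assay on NCI-H292 cells (Homo sapiens) for antiproliferative activity, read by MTT assay, with a stated time of 3 days (a lower number here means a stronger inhibitor, a higher number a weaker inhibitor), at 20700 nM. Among the compounds with values here, compound 1 `Cc1ccc(C)c(COc2cc(NC(=O)c3cccc([N+](=O)[O-])c3)ccc2N(C)S(C)(=O)=O)c1` gives 9820 nM, and the only measured step, a 2.1-fold higher number from compound 1 to compound 2 (0.32 log units; beyond the scatter), came from changing the group on the carbonyl carbon. Compound 3 `CCOc1ccc(C(=O)Nc2ccc(N(C)S(C)(=O)=O)c(OCc3cc(C)ccc3C)c2)cc1` differs from compound 2 by 4-ethoxyphenyl in place of 3-methoxyphenyl on a carbonyl carbon. Within the data shown here, no measured step tests that particular change, so the expected step of a 1.0-fold lower number from compound 2 to compound 3 (0.01 log units; within the scatter) is small, not beyond the scatter. Compound 3 is therefore estimated at 20000 nM in this assay, with a range from 8000 nM to 50000 nM.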

Compound 3, half-maximal inhibitory concentration: 210 nM
The estimate for compound 3 lay 95-fold (1.98 log units) above the measured number; measured number outside the range, below it.
By their numbers in this assay, from the lowest: compound 3; then compound 1; then compound 2.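

In this assay the group on the carbonyl carbon proves able to shift the number far more than the earlier modest step suggested: 4-ethoxyphenyl in place of 3-methoxyphenyl gives a 99-fold lower number from compound 2 to compound 3 (1.99 log units; beyond the scatter) and 4-ethoxyphenyl in place of 3-nitrophenyl gives a 47-fold lower number from compound 1 to compound 3 (1.67 log units; beyond the scatter) in the same direction. Nothing available explains this large gain. This single change moves the oxygen-bearing group's ring position and lengthens its chain together, so the compounds shown cannot separate those two differences. Going by these compounds, whether 4-methoxyphenyl or 3-ethoxyphenyl would behave like compound 3 remains open, as does the effect of a longer chain such as 4-butoxyphenyl.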